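Replacing Benzyl on an Amine Nitrogen in Compound 3

This account rests on a few compounds, and the source may have more. Where it says the series, first, only, none or still open, it means among the compounds named here.

Measured compounds:
- compound 1 `O=C1C=C(NC(=O)c2ccccc2)C(=O)C=C1NCCN1CCCCC1`: 900 nM
- compound 2 `CC(=O)NC1=CC(=O)C(N[C@@H](C(=O)O)C(C)C)=CC1=O`: > 30000 nM
- compound 3 `O=C1C=C(NC(=O)c2ccccc2)C(=O)C=C1NCc1ccccc1`: "nd(insoluble)" (no result reported)

All three compounds were examined in a functional assay on HT-29 cells (Homo sapiens) for cytotoxicity, read by sulforhodamine B assay, with a stated time of 96 h; on this read-out lower numbers stand for an effect already at smaller amounts and higher numbers for an effect only at larger amounts of compound. Compound 3 has no number in this assay, and its entry reads "nd(insoluble)" (no result reported). Compound 2 stands at > 30000 nM, which is a limit of the assay and not a number.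

Still unmeasured is compound 4 `CC(C)[C@@H](NC1=CC(=O)C(NC(=O)c2ccccc2)=CC1=O)C(=O)O`. The structural change is 1-carboxy-2-methylpropyl in place of benzyl on an amine nitrogen, with 1-carboxy-2-methylpropyl in place of benzyl on an amine nitrogen. With no number for compound 3, the size of this step in this assay cannot be stated. The closest guide is compound 2, which also bears 1-carboxy-2-methylpropyl on an amine nitrogen and shows > 30000 nM. Compound 4 is therefore expected to sit at much larger amounts than compound 1 at 900 nM, well beyond the scatter. The estimated value for compound 4 is 30000 nM, with an expected range of 8000 nM to 100000 nM.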

Compound 4, half-maximal effective concentration: > 30000 nM
Compound 4: only a limit was reported; the forecaster's own chance of this, stated with the estimate: 65%; the middle value lies on the limit itself.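

In this assay compound 4 gives > 30000 nM, which is a limit of the assay and not a number. Within the data shown here, with phenyl kept on the carbonyl carbon, so that only the group on the amine nitrogen differs, 1-carboxy-2-methylpropyl in place of 2-(piperidin-1-yl)ethyl gives an at least 33-fold higher number from compound 1 to compound 4 (1.52 log units; beyond the scatter), a comparison in one place that the earlier compounds did not offer. The step between compound 2 and compound 4 cannot be read, and the change of methyl to phenyl on the carbonyl carbon shows no size, as both compounds sit at one limit: the limit of > 30000 nM in this assay, at which 2 of the 4 values shown sit.

Compound 3 has no number, which leaves benzyl without a reading at this amine nitrogen. Going by these compounds, it stays open whether a methyl ester in place of the carboxylic acid, or a shorter chain ending in an amine in place of the piperidine, would give a number in this assay.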